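The compounds below may be only part of what the source reports. "The series", "measured", "known", "first", "only" and "open" are said of these compounds alone.

Compound 1 `COc1cc(/C=C/c2ccc(NC(=O)/C=C/c3ccc(OC)c(OC)c3)cc2)cc(OC)c1` gives 960 nM in a functional assay on HT-29 cells (Homo sapiens) for inhibition, read by MTT assay, with a stated time of 48 h; on this read-out higher numbers stand for weaker inhibition and lower numbers for stronger inhibition. Compound 2 `COc1cc(/C=C/c2ccc(NC(=O)/C=C/c3ccc(C#N)cc3)cc2)cc(OC)c1` gives 3320 nM in this assay and stands highest of the two numbers, the step being a 3.5-fold higher number from compound 1 to compound 2 (0.54 log units; beyond the scatter). Compound 3 `COc1cc(/C=C/c2ccc(NC(=O)/C=C/c3ccc(O)c(O)c3)cc2)cc(OC)c1` differs from compound 2 in one place: 3,4-dihydroxyphenyl in place of 4-cyanophenyl on a double-bonded chain carbon bound to a double-bonded chain carbon. Among the compounds with values here, the only step that bears on it is the one from compound 1 to compound 2, where swapping a ring bearing two methoxy groups for a 4-cyanophenyl raised the number. Putting a 3,4-dihydroxyphenyl in should partly reverse that, so a lower number is expected. The expected step is a 2.6-fold lower number from compound 2 to compound 3 (0.41 log units; beyond the scatter). Compound 3 is therefore estimated at 1300 nM, within a range of 450 nM to 3800 nM.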

Compound 3, half-maximal inhibitory concentration: 1560 nM
The estimate for compound 3 lay 1.2-fold (0.08 log units) below the measured number, within the range that was stated.
By their numbers in this assay, from the lowest: compounds 1 and 3 (each within the scatter of the next); then compound 2.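

In this assay, the place on a double-bonded chain carbon bound to a double-bonded chain carbon now shows a second group that does better than 4-cyanophenyl, with 3,4-dihydroxyphenyl giving a 2.1-fold lower number from compound 2 to compound 3 (0.33 log units; beyond the scatter). Exchanging the two methoxy groups for two hydroxy groups gives a 1.6-fold higher number from compound 1 to compound 3 (0.21 log units; within the scatter), so these two rings cannot be told apart here. Nothing measured here explains the difference from the 4-cyanophenyl compound. Within the data shown here, still open is whether a ring with only one hydroxy group would match compound 3. Also open, on these data alone, is how an amine or a carboxylic acid would fare in place of the nitrile.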